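Carbamoyl on the Shared Core: Expected Effect on Potency

The compounds below may be only part of what the source reports. "The series", "measured", "known", "first", "only" and "open" are said of these compounds alone.

Among the measured compounds shown here, compound 2 `CC1CN(c2cnc3cnn(C(C)c4ccc(Cl)cc4Cl)c3n2)CCC1N1CCCCC1` is one of two compounds measured in a functional assay on cells for antagonist activity at C-C chemokine receptor type 4 (Homo sapiens), read by fluorescence and calcium flux, with stated times of 2.5 s and 45 s (a higher number here means a weaker inhibitor, a lower number a stronger inhibitor), where compound 2 gives 238 nM. Compound 1 `Cc1nn(C(C)c2ccc(Cl)cc2Cl)c2nc(N3CCC(N4CCCCC4)C(C)C3)cnc12` gives 126 nM, and the two numbers lie within the scatter of each other: a 1.9-fold higher number from compound 1 to compound 2 (0.28 log units; within the scatter). Compound 3 `CC1CN(c2cnc3c(C(N)=O)nn(C(C)c4ccc(Cl)cc4Cl)c3n2)CCC1N1CCCCC1` differs from compound 2 at that same aromatic carbon: carbamoyl in place of hydrogen on an aromatic carbon. For the measured compounds named here, the one measured step concerns the same carbon but a different group, so it guides only weakly. A small shift toward a higher number is expected for compound 3, namely a 1.5-fold higher number from compound 2 to compound 3 (0.17 log units; within the scatter), giving an estimate of 350 nM with a range from 100 nM to 1200 nM.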

Compound 3, half-maximal inhibitory concentration: 228 nM
Compound 3: middle estimate off by 1.5-fold (0.19 log units), on the high side, and the stated range covers the measured number.
By their numbers in this assay, from the lowest: compounds 1, 3 and 2 (each within the scatter of the next).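

Putting carbamoyl, with its 3 heavy atoms, on this aromatic carbon gives a 1.0-fold lower number from compound 2 to compound 3 (0.02 log units; within the scatter), so this larger group leaves the number within the scatter of hydrogen. Set against methyl at the same carbon, carbamoyl gives a 1.8-fold higher number from compound 1 to compound 3 (0.26 log units; within the scatter), which is also within the scatter, so hydrogen, methyl and carbamoyl cannot be told apart here. No measurement on hand explains why this position tolerates all three groups.

From the compounds shown here alone, whether an amine, a carboxylic acid or a longer chain on this carbon would also stay within the scatter remains open.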